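This account rests on a few compounds, and the source may have more. Where it says the series, first, only, none or still open, it means among the compounds named here.

Measured so far in a functional assay on DU-145 cells (Homo sapiens) for inhibition, read by sulforhodamine B assay, with a stated time of 48 h, tested at 1 uM; on this read-out lower numbers stand for a stronger effect and higher numbers for a weaker effect at the one concentration tested:
compound 1 `O=C(Nc1cccc(-n2cc(-c3ccncc3)c(-c3cc(O)cc(Cl)c3)n2)c1)Nc1ccc(Cl)c(Cl)c1`, 90%
compound 2 `COc1cc(Cl)cc(-c2nn(-c3cccc(NC(=O)Nc4cc(C(F)(F)F)cc(C(F)(F)F)c4)c3)cc2-c2ccncc2)c1`, 27%
compound 3 `COc1cc(Cl)cc(-c2nn(-c3cccc(NC(=O)Nc4ccc(Cl)c(Cl)c4)c3)cc2-c2ccncc2)c1`, 93%

Within the data shown here, compound 3 and compound 1 sit within the scatter of each other; the one step that joins them, a number 3 percentage points higher from compound 1 to compound 3 (within the scatter), is a methyl-for-hydrogen exchange on an aromatic oxygen and says nothing about the urea end. Among the measured compounds shown here, compound 2 gives a number far below both, and it differs from compound 3 at that urea end only, with no single step between them.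

Compound 4 `COc1cc(Cl)cc(-c2nn(-c3cccc(NC(=O)c4cccc(C(F)(F)F)c4)c3)cc2-c2ccncc2)c1` is compound 3 altered at the carbonyl carbon: 3-(trifluoromethyl)phenyl in place of (3,4-dichlorophenyl)amino on a carbonyl carbon. For the measured compounds named here, no measured step covers this change. Going by the values given here, the only pointer is that compound 2, carrying trifluoromethyl groups at this end, reads much lower than compound 3, so a downward step is expected but with wide uncertainty, a number 33 percentage points lower from compound 3 to compound 4 (beyond the scatter). Compound 4 is estimated at 60%, between 20% and 100%.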

Compound 4, a percentage reported as activity, at one concentration (the size of the read-out at that concentration, not a potency): 100%
For compound 4 the middle estimate is 40 percentage points below the measured one; low and high end bracket the measured number.
By their numbers in this assay, from the lowest: compound 2; then compounds 1, 3 and 4 (each within the scatter of the next).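

In this assay, the exchange at the carbonyl carbon gives a number 7 percentage points higher from compound 3 to compound 4 (within the scatter). Here (3,4-dichlorophenyl)amino can therefore give way to 3-(trifluoromethyl)phenyl, with the loss of that hydrogen-bond donor, without a change beyond the scatter, so one trifluoromethyl group on this amide does not lower the number. No supporting data bear on this result. Open, from the compounds shown here alone, is whether the low number of compound 2 depends on the urea, its two trifluoromethyl groups, or both. Also open, going by these compounds, is how this amide would read with a nitrile or a dimethylamino group on its phenyl ring.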